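Trimming a Methoxy Group: What Is Expected of Compound 4

The source may report more compounds than this note shows. Statements on the series, on what has been measured and on what is new or still open speak of the compounds shown alone.

Measured compounds:
Compound 1, `COc1cc(-c2cc(/C=C/C(=O)c3ccc(N)cc3)[nH]n2)cc(OC)c1OC`, in a functional assay on SK-MEL-5 cells (Homo sapiens) for cytotoxicity, read by sulforhodamine B assay, with a stated time of 48 h, tested at 1 uM (a higher number here means a weaker effect of the compound at the concentration tested, a lower number a stronger effect), compound 1 gives 90%.
Compound 2, `COc1ccc(-c2cc(/C=C/C(=O)c3ccc(OC)c(OC)c3)[nH]n2)cc1`, in this assay compound 2 gives 88%.
Compound 3, `COc1cc(-c2cc(/C=C/C(=O)c3ccc(Cl)c(Cl)c3)[nH]n2)cc(OC)c1OC`, in this assay compound 3 gives 94%.

Compound 1 stands second highest of the three numbers. Its nearest neighbour is compound 2, and the step of a number 4 percentage points higher from compound 1 to compound 3 (within the scatter) lies within the scatter, so all three measured compounds show only a weak effect at the tested concentration and cannot be told apart.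

Compound 4, `COc1ccc(-c2cc(/C=C/C(=O)c3ccc(N)cc3)[nH]n2)cc1OC`, is compound 1 with one change: hydrogen in place of methoxy on an aromatic carbon. For the measured compounds named here, none of the measured steps touches this position; the single step on record, a number 4 percentage points higher from compound 1 to compound 3 (within the scatter), concerns the other end of the molecule and was within the scatter. Compound 2, which also carries fewer methoxy groups on that ring but differs from compound 1 in two places, gives a number within the scatter of compound 1. With no evidence that a change of this kind moves the read-out, the expectation for this assay is no step beyond the scatter.

Compound 4 is therefore estimated at 91%, with a range from 80% to 100%, which is expected to amount to a number 1 percentage points higher from compound 1 to compound 4 (within the scatter).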

Compound 4, a percentage reported as activity, at one concentration (the size of the read-out at that concentration, not a potency): 94%
Compound 4: middle estimate off by 3 percentage points, on the low side; the range from low to high includes it.
By their numbers in this assay, from the lowest: compounds 2, 1, 3 and 4 (each within the scatter of the next).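

With hydrogen in place of methoxy on an aromatic carbon, ortho to a methoxy group and meta to a large group, this assay gives a number 4 percentage points higher from compound 1 to compound 4 (within the scatter), and this position now has a step of its own. Until now the only hint about the methoxy groups on that ring came from compound 2, which differs from compound 1 in two places; this step isolates a single change and shows that losing this methoxy group leaves the read-out within the scatter. Since compound 1 and compound 4 both show only a weak effect at the one concentration tested, this says little about what the position could contribute in a more active compound, and nothing available offers an explanation for the result.

On these data alone, it remains open whether a different group on this carbon, such as a hydroxyl, an amine or a longer ether chain like ethoxy, would move the read-out beyond the scatter. As far as these compounds go, it is equally open whether the same change would behave alike with the 3,4-dichlorophenyl group of compound 3 on the carbonyl carbon.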